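From a 3-fluorobenzyl to a 2-methoxybenzyl group at a limit

A few compounds are considered here, and "the series" means these few. Any claim that something is new, unique, unknown or untested is made for them only; others in the source may bear on it.

Measured so far in a physicochemical assay for solubility, using the shake flask method, in simulated intestinal fluid, measured as kinetic solubility, with a stated time of 2 h, at 25 degrees C, at pH 6.5 (on this read-out lower numbers stand for lower solubility and higher numbers for higher solubility), are three compounds.
- compound 1 `Cc1nc(C#N)c(N)c2c1C(=O)N(Cc1ccccc1)C2=O` gives < 5000 nM (a limit)
- compound 2 `Cc1noc(-c2nc(C)c3c(c2N)C(=O)N(Cc2ccc(C(F)(F)F)cc2)C3=O)n1` gives < 5000 nM (a limit)
- compound 3 `Cc1noc(-c2nc(C)c3c(c2N)C(=O)N(Cc2cccc(F)c2)C3=O)n1` gives < 5000 nM (a limit)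

Compound 3 has no number of its own, only < 5000 nM as a limit of the assay. All the readings so far rest on the limit of < 5000 nM in this assay, at which 3 of the 3 values shown sit, and none of them is a number.

Compound 4 `COc1ccccc1CN1C(=O)c2c(C)nc(-c3nc(C)no3)c(N)c2C1=O` carries 2-methoxyphenyl in place of 3-fluorophenyl on a saturated chain carbon bound to an amide-type nitrogen in a ring, and the count of this change is 2-methoxyphenyl in place of 3-fluorophenyl on a saturated chain carbon bound to an amide-type nitrogen in a ring while the rest of the structure stays the same.

For the measured compounds named here, the one measured step at this place is a step that the two limits leave unreadable from compound 2 to compound 3 and it gives no size to carry over. No step beyond the usual scatter is therefore expected in this assay and no direction can be named. The estimated change is a step that the limit leaves unreadable from compound 3 to compound 4 for this swap. Compound 4 is expected to give 4000 nM as an estimate, within an expected range from 1500 nM to 9000 nM and quite possibly reported again as a limit.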

Compound 4, solubility: < 5000 nM
Compound 4: no number, only a limit (the forecaster's own chance of this, stated with the estimate: 80%); the middle value is on the limit's open side.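

No step can be read from compound 2 or compound 3 to compound 4, as compound 4 again gives only a limit in this assay, and all the readings rest on it: the limit of < 5000 nM in this assay, at which 4 of the 4 values shown sit.

The compounds shown leave open what number any of them would give and whether the groups exchanged make any difference to the read-out.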